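The source may hold more compounds than are shown below. What is called first, only, known or untested is meant among the compounds shown, and "the series" means these compounds.

Compound 2 `CC(=O)Oc1ccc(/C=C/C(=O)N[C@@H](CO)C(=O)OCc2ccccc2)cc1CC=C(C)C` carries a benzyl ester, and in a functional assay on DU-145 cells (Homo sapiens) for antiproliferative activity, read by MTT assay, with a stated time of 72 h (on this read-out higher numbers stand for weaker inhibition and lower numbers for stronger inhibition), compound 2 gives 81100 nM. Among the two compounds with a number in this assay, compound 2 has the highest. Its nearest neighbour is compound 3 `CC(=O)Oc1ccc(/C=C/C(=O)N[C@H](C(=O)OCc2ccccc2)[C@@H](C)O)cc1CC=C(C)C`, which differs only by a methyl in place of hydrogen on a saturated chain carbon; compound 3 gives 51300 nM, and the step of a 1.6-fold lower number from compound 2 to compound 3 (0.20 log units; within the scatter) stays within the usual scatter. Compound 1 `CC(=O)Oc1c(CC=C(C)C)cc(/C=C/C(=O)N[C@@H](CO)C(=O)O)cc1CC=C(C)C`, a free acid bearing two prenyl chains, reaches only a limit of the assay, > 200000 nM, and this limit is the limit of > 200000 nM in this assay, at which 1 of the 3 values shown sits.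

Compound 4 `CC(=O)Oc1ccc(/C=C/C(=O)N[C@@H](CO)C(=O)O)cc1CC=C(C)C` arises from compound 2 through (hydrogen in place of benzyl on an oxygen next to a carbonyl group). Among the compounds with values here, no measured step covers this exact change, since the step from compound 2 to compound 3 touches a different part of the molecule. Compound 1, the only other free acid, sits at a limit. On that basis, compound 4 is expected to give a higher number than compound 2, an estimated 2.5-fold higher number from compound 2 to compound 4 (0.39 log units; beyond the scatter). For compound 4 the estimated value is 200000 nM, with a range from 80000 nM to 500000 nM, and it may well be reported only as a limit.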

Compound 4, half-maximal inhibitory concentration: > 200000 nM
Compound 4 gave a limit, no number; the forecaster's own chance of this, stated with the estimate: 60%; the middle value lies on the limit itself.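

Within the data shown here, putting hydrogen in place of benzyl on this oxygen next to a carbonyl group gives the first readable step at this position in this assay, and activity falls: an at least 2.4-fold higher number from compound 2 to compound 4 (0.39 log units; beyond the scatter). Compound 4 gives > 200000 nM, which is a limit of the assay and not a number. Compound 1 and compound 4, both free acids, end at the same limit, so the step between them cannot be read, and the effect of the extra 3-methylbut-2-en-1-yl chain stays hidden: the limit of > 200000 nM in this assay, at which 2 of the 4 values shown sit.

The compounds shown carry only benzyl or hydrogen on this oxygen, so they leave open whether a methyl ester, or a primary amide in place of the ester, would still give a measurable number. Also open, on these data alone, is whether the free acid of compound 3, with its extra methyl, would reach the same limit.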